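Second chloro added to the aryl ring of compound 2

The compounds below may be only part of what the source reports. "The series", "measured", "known", "first", "only" and "open" are said of these compounds alone.

For the measured compounds named here, in a physicochemical assay for lipophilicity (a lower number here means a more polar compound, a higher number a more lipophilic compound), compound 2 `Clc1ccccc1C1=NC(c2ccccc2)CO1` gives 3.56, the lower of the two numbers so far; compound 1 `CCOc1ccccc1C1=NC(c2ccccc2)CO1` gives 4.22. Going by the values given here, the only measured step, a number 0.66 log units lower from compound 1 to compound 2 (beyond the scatter), swaps one group for another and does not bear directly on adding a group to hydrogen. Compound 3 `Clc1ccc(Cl)c(C2=NC(c3ccccc3)CO2)c1` differs from compound 2 by chloro in place of hydrogen on an aromatic carbon. Among the compounds with values here, with no directly comparable step, the expected change is a number 0.69 log units higher from compound 2 to compound 3 (beyond the scatter), an increase in this assay beyond the scatter. Compound 3 is therefore estimated at 4.25, in the range 3.9 to 4.6.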

Compound 3, partition coefficient: 4.4
Estimate against measurement, compound 3: 0.15 log units below, within the range that was stated.
By their numbers in this assay, from the lowest: compound 2; then compounds 1 and 3 (each within the scatter of the next).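

In this assay the new change reads a number 0.84 log units higher from compound 2 to compound 3 (beyond the scatter). For the compounds shown here, it is the first measured case of a group entering in place of hydrogen, since the earlier step only exchanged one group for another. Going by these compounds alone, it is also the first reading at this place, on an aromatic carbon meta to a large group and para to a chloro group, and it is a single step. On these data alone, whether an amine or a carboxylic acid at the same place would give a step of similar size or direction stays open, as does the size of the chloro step on other aromatic carbons. Nothing available accounts for the size of this step.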